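This account rests on a few compounds, and the source may have more. Where it says the series, first, only, none or still open, it means among the compounds named here.

Compound 1 `CN1CCC(C(=O)N2Cc3c(NC(=O)c4cc(F)cc(F)c4)n[nH]c3C2(C)C)CC1` is one of two compounds for which a measurement exists here. In a physicochemical assay for solubility, at pH 7 (on this read-out lower numbers stand for lower solubility and higher numbers for higher solubility), compound 1 gives > 225000 nM, which is a limit of the assay and not a number. Compound 2 `CN1CCN(C(=O)N2Cc3c(NC(=O)c4ccc(F)cc4)n[nH]c3C2(C)C)CC1` shares the same core with a different amide and a different acyl group. In this assay compound 2 gives > 225000 nM, again a limit rather than a measured number. Compound 1 therefore stands at the limit of > 225000 nM in this assay, at which 2 of the 2 values shown sit, and nothing in the two values sets it apart from compound 2. Within the data shown here, no step between measured compounds that differ in a single place is available, so the size of any single change in this assay is unknown from the data.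

The unmeasured compound 3 `CN1CCC(C(=O)N2Cc3c(NC(=O)c4ccncc4)n[nH]c3C2(C)C)CC1` differs from compound 1 by pyridin-4-yl in place of 3,5-difluorophenyl on a carbonyl carbon. The step from compound 1 to compound 3 in this assay is expected to be a step that the limit leaves unreadable from compound 1 to compound 3, that is none beyond the scatter, since compound 1 already sits at the limit of > 225000 nM in this assay, at which 2 of the 2 values shown sit. Compound 3 is estimated at 300000 nM, within 150000 nM to 600000 nM, and is expected most likely to be reported once more only as a limit.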

Compound 3, solubility: > 225000 nM
Compound 3: no number, only a limit (the forecaster's own chance of this, stated with the estimate: 85%); the middle value does not contradict the limit.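

No step from compound 1 to compound 3 can be read in this assay, because both compounds are reported only as a limit of the assay and not as a number: the limit of > 225000 nM in this assay, at which 3 of the 3 values shown sit.

The compounds shown leave open how far each lies beyond that limit, and whether any change to them would give a readable number.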